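Phenol Alkylation on an Oxadiazole Thioether Series

This account rests on a few compounds, and the source may have more. Where it says the series, first, only, none or still open, it means among the compounds named here.

Measured so far:
Compound 1 `COc1cc(-c2nnc(SCc3ccccc3C)o2)ccc1O` — in an ADME assay on cells (Mus musculus, strain BALB/c) for cytotoxicity, read by MTT assay, with a stated time of 24 h (a lower number here means that less compound is tolerated, a higher number that more compound is tolerated), compound 1 gives 592000 nM.
Compound 2 `COc1cccc(CSc2nnc(-c3ccc(O)c(OC)c3)o2)c1` — in this assay compound 2 gives 389000 nM.

Compound 2 sits alongside compound 1: a 1.5-fold lower number from compound 1 to compound 2 (0.18 log units; within the scatter). Compound 3 `COc1cccc(COc2ccc(-c3nnc(SCc4cccc(OC)c4)o3)cc2OC)c1` differs from compound 2 by 3-methoxybenzyl in place of hydrogen on an oxygen on an aromatic ring. Among the measured compounds shown here, no measured step touches this oxygen; the only step available concerns the group on the sulfur-bound carbon and stayed within the scatter, so it gives no direct guide. Only a small change is therefore expected in this assay, estimated as a 1.6-fold lower number from compound 2 to compound 3 (0.19 log units; within the scatter). For compound 3 the estimate is 250000 nM, expected to fall between 100000 nM and 550000 nM.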

Compound 3, half-maximal cytotoxic concentration: 242000 nM
For compound 3 the middle estimate is 1.0-fold (0.01 log units) above the measured one; the measured number falls inside the stated range.
By their numbers in this assay, from the lowest: compounds 3, 2 and 1 (each within the scatter of the next, the first and the last beyond it).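

In this assay, among the compounds shown here, the change from hydroxy to (3-methoxybenzyl)oxy on the oxygen on the aromatic ring gives a 1.6-fold lower number from compound 2 to compound 3 (0.21 log units; within the scatter) and is the first measured change at this oxygen. Even with 9 heavy atoms and an added six-membered aromatic ring entering there, the step stays within the scatter, so this position tolerates a large group in this read-out. Nothing measured here accounts for this result.

Open, from the compounds shown here alone, is whether a small alkyl such as ethyl, an amine or a carboxylic acid on this oxygen would behave the same way. Also open, going by these compounds, is whether the same change holds with 2-methylphenyl on the sulfur-bound carbon.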